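A Sulfanyl Leaves, an Amino Enters: Expectations for Compound 3

A few compounds are considered here, and "the series" means these few. Any claim that something is new, unique, unknown or untested is made for them only; others in the source may bear on it.

Compound 1 `CC(=O)OCc1ccc2oc(=O)c(C(=O)Sc3cccc(Cl)c3)cc2c1` and compound 2 `CC(=O)OCc1ccc2oc(=O)c(C(=O)Sc3cccc(Br)c3)cc2c1` share one core and differ only in bromo in place of chloro on an aromatic carbon. In a functional assay on HT-1080 cells (Homo sapiens), read by transwell migration, with a stated time of 24 h, tested at 1 uM (a higher number here means a weaker effect of the compound at the concentration tested, a lower number a stronger effect), compound 1 gives 65.8%, and compound 2 gives 70.9%; the step of a number 5.1 percentage points higher from compound 1 to compound 2 (within the scatter) lies within the scatter. Compound 2 thus stands highest of the two numbers, with compound 1 nearest and within the scatter, so the two cannot be told apart in this assay.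

Compound 3 `CC(=O)OCc1ccc2oc(=O)c(C(=O)N(C)c3ccc(Cl)cc3)cc2c1` carries (4-chlorophenyl)(methyl)amino in place of (3-bromophenyl)sulfanyl on a carbonyl carbon. Going by the values given here, the only measured step does not bear on an exchange of the whole group on the carbonyl carbon, and it moved the read-out by a number 5.1 percentage points higher from compound 1 to compound 2 (within the scatter), which is within the scatter. Among the compounds with values here, no measured pair speaks to sulfanyl against amino on that carbon. Compound 3 is therefore expected near compound 2, at 68% with a range of 50% to 86%. The expected step is a number 2.9 percentage points lower from compound 2 to compound 3 (within the scatter), not beyond the scatter.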

Compound 3, a percentage reported as activity, at one concentration (the size of the read-out at that concentration, not a potency): 98.6%
Beside the measured number, compound 3's estimate is 30.6 percentage points below it; measured number above the stated range.
By their numbers in this assay, from the lowest: compounds 1 and 2 (each within the scatter of the next); then compound 3.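

The group on the carbonyl carbon proved to be a position where the read-out moves well beyond what the halogen exchange showed: in this assay, putting (4-chlorophenyl)(methyl)amino in place of the sulfanyl groups gives a number 27.7 percentage points higher from compound 2 to compound 3 (beyond the scatter) and a number 32.8 percentage points higher from compound 1 to compound 3 (beyond the scatter). Both steps point the same way, so compound 3 has the weakest effect of the three at the concentration tested, while the bromo and chloro sulfanyl compounds remain indistinguishable. No supporting measurement bears on why this exchange changes the read-out.

The exchange alters the linking atom, the methyl and the halogen together, so the compounds shown cannot assign the step to any one of these. Going by these compounds, how a phenoxy group or a (3-chlorophenyl)amino group on that carbonyl carbon would read in this assay remains open.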